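A few compounds are considered here, and "the series" means these few. Any claim that something is new, unique, unknown or untested is made for them only; others in the source may bear on it.

Measured in a functional assay on CCRF-CEM cells (Homo sapiens) for inhibition, read by MTT assay, with a stated time of 72 h (on this read-out lower numbers stand for stronger inhibition and higher numbers for weaker inhibition), compound 1 (`COc1cccc(/C=C/C(=O)Nc2cc(OC)c(OC)c(OC)c2)c1`) gives 23400 nM and compound 2 (`C=C(Br)C(=O)Nc1cccc(/C=C/C(=O)Nc2cccc3ccccc23)c1`) gives 1800 nM while compound 3 (`C=C(Br)C(=O)Nc1cccc(/C=C/C(=O)Nc2ccc(F)c(F)c2)c1`) reaches 13 nM as the lowest of the three, beyond the scatter from both others. Compound 4 (`C=C(Br)C(=O)Nc1cccc(/C=C/C(=O)Nc2ccc(OC)cc2)c1`) carries 4-methoxyphenyl in place of 3,4-difluorophenyl on an amide-type nitrogen. Among the compounds with values here, no measured pair isolates a single change, so the guide is thin: compound 2 (1800 nM) stands far above compound 3 (13 nM) and shows how much the numbers can spread. A step of a 12-fold higher number from compound 3 to compound 4 (1.06 log units; beyond the scatter) is therefore expected in this assay toward a higher number, beyond the scatter. For compound 4 the estimated value is 150 nM with an expected range of 20 nM to 1200 nM around it.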

Compound 4, half-maximal inhibitory concentration: 26 nM
Beside the measured number, compound 4's estimate is 5.8-fold (0.76 log units) above it; low and high end bracket the measured number.
By their numbers in this assay, from the lowest: compounds 3 and 4 (each within the scatter of the next); then compound 2; then compound 1.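

In this assay the exchange of 3,4-difluorophenyl for 4-methoxyphenyl on the amide-type nitrogen gives a 2.0-fold higher number from compound 3 to compound 4 (0.30 log units; within the scatter) and is the only single-place comparison among these compounds. At this position, the two groups cannot be told apart by this read-out, although they differ in their atoms and in hydrogen-bond acceptor count. No supporting measurement accounts for this result. From the compounds shown here alone, it remains open whether an aminophenyl or a carboxyphenyl group on the same nitrogen would stay within the scatter of these two. A longer alkyl chain there is equally unresolved.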